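The source may hold more compounds than are shown below. What is called first, only, known or untested is meant among the compounds shown, and "the series" means these compounds.

In a functional assay on A549 cells (Homo sapiens) for inhibition, read by sulforhodamine B assay, with a stated time of 72 h (on this read-out higher numbers stand for weaker inhibition of growth and lower numbers for stronger inhibition of growth), compound 1 `CNC(=O)/C=C/c1ccncc1-c1ccc2ccccc2c1` gives 6620 nM. Compound 2 `NC(=O)/C=C/c1ccncc1-c1ccc2ccccc2c1` gives > 10000 nM, which is a limit of the assay and not a number. Compound 3 `O=C(O)CCc1ccncc1-c1ccc2ccccc2c1` differs from compound 2 in its side chain: 2-carboxyethyl in place of 2-carbamoylethenyl on an aromatic carbon. Among the compounds with values here, the only measured step, an at least 1.5-fold higher number from compound 1 to compound 2 (0.17 log units; that floor lies within the scatter), lies on the amide nitrogen, a group that compound 3 no longer has, so it offers only a loose guide. The expected step is small, a step that the limit leaves unreadable from compound 2 to compound 3, and no shift beyond the scatter is anticipated. For compound 3 the estimate is 12000 nM, with an expected range of 5000 nM to 30000 nM.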

Compound 3, concentration for 50% growth inhibition: > 10000 nM
Compound 3: a limit, no number (the forecaster's own chance of this, stated with the estimate: 70%); the middle value does not contradict the limit.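

In this assay compound 3, with its 2-carboxyethyl side chain, gives > 10000 nM, which is a limit of the assay and not a number. Swapping the 2-(methylcarbamoyl)ethenyl side chain for 2-carboxyethyl gives an at least 1.5-fold higher number from compound 1 to compound 3 (0.17 log units; that floor lies within the scatter), so even this larger change shows no shift that can be claimed. The step between compound 2 and compound 3 cannot be read, and this position remains unresolved in this assay: the limit of > 10000 nM in this assay, at which 2 of the 3 values shown sit.

On these data alone, whether a methyl ester or an amine at this position would give a readable number stays open. So does whether a longer chain would.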